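This account rests on a few compounds, and the source may have more. Where it says the series, first, only, none or still open, it means among the compounds named here.

In a toxicity assay on MT4 cells (Homo sapiens) for cytotoxicity, read by MTT assay, with a stated time of 5 days (a higher number here means that more compound is tolerated, a lower number that less compound is tolerated), compound 1 (`Cc1cnc(Nc2ccc(C#N)cc2)nc1Nc1c(F)cc(-c2ccc(C#N)nc2)cc1F`) gives 62000 nM, compound 2 (`Cc1cc(-c2cccs2)cc(C)c1Nc1ccnc(Nc2ccc(C#N)cc2)n1`) gives 10000 nM and compound 3 (`Cc1cc(-c2cncnc2)cc(C)c1Nc1ccnc(Nc2ccc(C#N)cc2)n1`) gives 6800 nM. Compound 3 thus stands well under compound 1 and level with compound 2 within the scatter. Next comes compound 4 (`Cc1cc(-c2cc3ccccc3s2)cc(C)c1Nc1ccnc(Nc2ccc(C#N)cc2)n1`), with 1-benzothiophen-2-yl in place of pyrimidin-5-yl on an aromatic carbon. Among the measured compounds shown here, the only measured step at this place is a 1.5-fold lower number from compound 2 to compound 3 (0.17 log units; within the scatter), with pyrimidin-5-yl in place of thiophen-2-yl, and it stays within the scatter. Going by these compounds, no step beyond the scatter is therefore expected in this assay, and the direction remains open. The expected step is a 1.2-fold higher number from compound 3 to compound 4 (0.07 log units; within the scatter). For compound 4 the estimated value is 8000 nM, with an expected range of 3000 nM to 25000 nM.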

Compound 4, half-maximal cytotoxic concentration: 138000 nM
Estimate against measurement, compound 4: 17-fold (1.24 log units) below, and the stated range ends below it.
By their numbers in this assay, from the lowest: compounds 3 and 2 (each within the scatter of the next); then compound 1; then compound 4.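

At this place, para to a large group, the number in this assay can move far: 1-benzothiophen-2-yl brings a 20-fold higher number from compound 3 to compound 4 (1.31 log units; beyond the scatter) in place of pyrimidin-5-yl, and a 14-fold higher number from compound 2 to compound 4 (1.14 log units; beyond the scatter) in place of thiophen-2-yl. Thiophen-2-yl and pyrimidin-5-yl, each a single aromatic ring, stayed within the scatter of each other, so among these three groups a step beyond the scatter appears only with the two-ring group. No measurement at hand accounts for this step. Open, going by these compounds, is whether naphthalen-2-yl would match 1-benzothiophen-2-yl, and whether an amine or a carboxylic acid at this place would shift the number at all.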